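Phenyl added to the chain carbon of an alkylated purine core

This account rests on a few compounds, and the source may have more. Where it says the series, first, only, none or still open, it means among the compounds named here.

Measured compounds:
compound 1, `CO/N=c1\[nH]cnc2c1[n+](C/C=C(\C)CC/C=C(/C)CCC=C(C)C)cn2C`, 28700 nM in a functional assay on ACHN cells (Homo sapiens) for cytotoxicity; a higher number here means a weaker inhibitor, a lower number a stronger inhibitor
compound 2, `CC(C)=CCC/C(C)=C\CC/C(C)=C/C[n+]1cn(C)c2nc[nH]/c(=N\OCc3ccccc3)c21`, 25200 nM in this assay
compound 3, `CO/N=c1\[nH]cnc2c1[n+](C/C=C(\C)CC/C=C(\C)CC/C=C(\C)CCC=C(C)C)cn2Cc1ccccc1`, 3400 nM in this assay

Compound 4, `CO/N=c1\[nH]cnc2c1[n+](C/C=C(\C)CC/C=C(\C)CC/C=C(\C)CCC=C(C)C)cn2C(c1ccccc1)c1ccccc1`, is not yet measured. From compound 3 to compound 4 the change is phenyl in place of hydrogen on a saturated chain carbon bound to an aromatic carbon and an aromatic nitrogen. The same kind of change is found from compound 1 to compound 2, (phenyl in place of hydrogen on a saturated chain carbon bound to an oxygen), where it made a step of a 1.1-fold lower number from compound 1 to compound 2 (0.06 log units; within the scatter). The two places differ: in the measured pair the carbon is bound to an oxygen, in the new pair to an aromatic carbon and an aromatic nitrogen. How the core of compound 3 differs from that of compound 1 is not broken down here. Since the earlier step lay within the scatter, a step of about a 1.1-fold lower number from compound 3 to compound 4 (0.05 log units; within the scatter) is expected for compound 4. Compound 4 is therefore estimated at 3000 nM, likely between 1200 nM and 8000 nM.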

Compound 4, half-maximal inhibitory concentration: 4750 nM
Estimate against measurement, compound 4: 1.6-fold (0.20 log units) below; measured number inside the range.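

In this assay, phenyl in place of hydrogen gives a 1.4-fold higher number from compound 3 to compound 4 (0.15 log units; within the scatter), a step too small to count as a real change. Set beside the earlier case, the change behaves alike on the two cores: the same change on two cores in this assay, a 1.1-fold lower number (0.06 log units; within the scatter) from compound 1 to compound 2 and a 1.4-fold higher number (0.15 log units; within the scatter) from compound 3 to compound 4, 1.6-fold (0.20 log units) apart, within the scatter of two such steps. This shows that the change left the number within the scatter in both pairs, but it does not show that the same would hold on other cores, and the carbon carrying the phenyl differs, bound to an oxygen in one pair and to an aromatic carbon and an aromatic nitrogen in the other.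

The compounds shown leave open whether an amine or a carboxylic acid on the same carbon would move the number beyond the scatter.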